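The source may hold more compounds than are shown below. What is called first, only, known or untested is meant among the compounds shown, and "the series" means these compounds.

Of the compounds shown here, three sharing one core have been measured in a functional assay on MGC-803 cells (Homo sapiens) for cytotoxicity, read by MTT assay, with a stated time of 72 h; a higher number here means a weaker inhibitor, a lower number a stronger inhibitor. Compound 1 `FC(F)(F)c1ccc(CSc2nc(N3CCCCC3)c3ccccc3n2)cc1` gives 18600 nM in this assay. Compound 3 `COc1cc(Nc2nc(SCc3ccc(C(F)(F)F)cc3)nc3ccccc23)cc(OC)c1`, in this assay, gives 8580 nM. Compound 2 `FC(F)(F)c1ccc(CSc2nc(Nc3ccccc3C(F)(F)F)c3ccccc3n2)cc1` reached only the limit of this assay, > 50000 nM, so its value is a bound rather than a number (the limit of > 50000 nM in this assay, at which 1 of the 3 values shown sits). The measured steps run an at least 2.6-fold higher number from compound 1 to compound 2 (0.42 log units; beyond the scatter), a 2.2-fold lower number from compound 1 to compound 3 (0.34 log units; beyond the scatter) and an at least 5.8-fold lower number from compound 2 to compound 3 (0.76 log units; beyond the scatter). Compound 4 `Fc1ccc(Nc2nc(SCc3ccc(C(F)(F)F)cc3)nc3ccccc23)cc1Cl` is not yet measured and differs from compound 2 as follows: 3-chloro-4-fluorophenyl in place of 2-(trifluoromethyl)phenyl on a nitrogen on an aromatic ring. The step that bears most on this change is the exchange of the same 2-(trifluoromethyl)phenyl for another aryl group, which gave an at least 5.8-fold lower number from compound 2 to compound 3 (0.76 log units; beyond the scatter); 3-chloro-4-fluorophenyl is a different group from 3,5-dimethoxyphenyl, so the size cannot be read across directly. Compound 4 is expected to come off the limit, with an estimated at least 3.3-fold lower number from compound 2 to compound 4 (0.52 log units; beyond the scatter). For compound 4 the estimated value in this assay is 15000 nM, within 5000 nM to 50000 nM.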

Compound 4, half-maximal inhibitory concentration: > 50000 nM
Compound 4 gave a limit, no number (the forecaster's own chance of this, stated with the estimate: 25%); at least 3.3-fold (0.52 log units) between middle value and limit.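

In this assay, compound 4 gives only a limit and not a number, as compound 2 does: the limit of > 50000 nM in this assay, at which 2 of the 4 values shown sit.

So replacing 2-(trifluoromethyl)phenyl with another aryl group on this nitrogen does not by itself bring a compound off the limit, and the lower number of compound 3 cannot be read as holding for aryl groups in general. Exchanging 3,5-dimethoxyphenyl for 3-chloro-4-fluorophenyl gives an at least 5.8-fold higher number from compound 3 to compound 4 (0.76 log units; beyond the scatter), and exchanging piperidin-1-yl for (3-chloro-4-fluorophenyl)amino gives an at least 2.6-fold higher number from compound 1 to compound 4 (0.42 log units; beyond the scatter), while the step between the two limit compounds cannot be read.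

The compounds shown leave open whether the methoxy groups of compound 3 account for its lower number. From the compounds shown here alone, an unsubstituted phenyl, a single methoxy or a hydroxyl on this ring could test that, and how far compound 2 and compound 4 lie past the limit also stays unknown.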